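Compound 2 to Compound 3: a Chain Swap on the Nitrogen

The source may report more compounds than this note shows. Statements on the series, on what has been measured and on what is new or still open speak of the compounds shown alone.

Compound 1, `CC(C)(C)Cc1ccc2nc(N)sc2c1`, in a functional assay on the whole organism with Rattus norvegicus as the target; a higher number here means that more compound is needed for the effect, a lower number that less compound is needed: compound 1 gives > 10 mg/kg, which is a limit of the assay and not a number.
Compound 2, `N#CCn1c(=N)sc2cc(OC(F)(F)F)ccc21`, in this assay: compound 2 gives 3.5 mg/kg.

Compound 2 holds the only number shown in this assay; the other value is a limit, so compound 2 has no measured neighbour against which it can be ranked. The result for compound 1 sits at the limit of > 10 mg/kg in this assay, at which 1 of the 2 values shown sits. Within the data shown here, compounds 1 and 2 differ in more than one place, and no step between them is recorded, so their two values show only that one is a number and the other a limit.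

Compound 3, `C[S+]([O-])CCn1c(=N)sc2cc(OC(F)(F)F)ccc21`, has not yet been measured in this assay. It differs from compound 2 by a group of 4 heavy atoms (2 carbon, 1 oxygen, 1 sulfur; no ring) in place of a group of 2 heavy atoms (1 carbon, 1 nitrogen; no ring), on a saturated chain carbon bound to an aromatic nitrogen. Among the measured compounds shown here, with no measured step to lean on, the expected step of a 1.4-fold higher number from compound 2 to compound 3 (0.15 log units; within the scatter) is put at none beyond the usual scatter, with a wide range allowed on either side. Compound 3 is estimated at 5 mg/kg, between 1.5 mg/kg and 15 mg/kg, with a real chance that only a limit is reported.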

Compound 3, dose for half-maximal effect: 1.1 mg/kg
Estimate against measurement, compound 3: 4.5-fold (0.66 log units) above, and the stated range ends above it.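

The chain on the aromatic nitrogen proves to be a place where the result in this assay can move: putting the group of 4 heavy atoms, with its sulfur and oxygen, in place of the cyano group gives a 3.2-fold lower number from compound 2 to compound 3 (0.50 log units; beyond the scatter). Among these compounds, this is the first step that can be read at all, and it shows that the effect in the whole animal does not depend on the cyano group, since compound 3 lacks it and still needs less compound than compound 2. Among the compounds shown here, nothing measured here gives a reason for this step, and the single pair cannot show which feature of the new group accounts for it.

The compounds shown leave open whether the lower number belongs to the sulfur and oxygen atoms or to the chain alone, a question that a plain alkyl chain, a longer chain, an amine or a carboxylic acid on a saturated chain carbon bound to an aromatic nitrogen could help to settle. Going by these compounds, it is also open whether the step carries over to the core of compound 1, whose > 10 mg/kg is a limit of the assay and not a number.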